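This account rests on a few compounds, and the source may have more. Where it says the series, first, only, none or still open, it means among the compounds named here.

Measured compounds in an ADME assay on HepG2 cells (Homo sapiens) for cytotoxicity, read by luminescence, CellTiter-Glo and ATP content, with a stated time of 72 h; on this read-out lower numbers stand for an effect already at smaller amounts and higher numbers for an effect only at larger amounts of compound:
- compound 1, `c1coc(CNCCCNc2ccnc3cc(-c4cccc5ccccc45)ccc23)c1`: 5600 nM
- compound 2, `COc1cccc(Oc2ccc3c(NCCCNCc4ccco4)ccnc3c2)c1`: 15500 nM
- compound 3, `Clc1ccc(Oc2ccc3c(NCCCNCc4ccco4)ccnc3c2)cc1`: 7800 nM

Compound 3 stands second highest of the three numbers. Its nearest neighbour is compound 1, a 1.4-fold higher number from compound 1 to compound 3 (0.14 log units; within the scatter), and its furthest is compound 2, a 2.0-fold lower number from compound 2 to compound 3 (0.30 log units; within the scatter); both of these gaps sit within the scatter, so on the present data compound 3 is not separated from either.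

The next compound is compound 4, `CN(C)c1cccc(Oc2ccc3c(NCCCNCc4ccco4)ccnc3c2)c1`. It differs from compound 3 in one place: 3-(dimethylamino)phenyl in place of 4-chlorophenyl on an oxygen on an aromatic ring.

Within the data shown here, the one measured step at the same place is the one between compound 2 and compound 3, a 2.0-fold lower number from compound 2 to compound 3 (0.30 log units; within the scatter), within the scatter. The other two steps, a 2.8-fold higher number from compound 1 to compound 2 (0.44 log units; beyond the scatter) and a 1.4-fold higher number from compound 1 to compound 3 (0.14 log units; within the scatter), replace the whole group on the aromatic carbon and bear only loosely on the present change; only the first of them reaches beyond the scatter. Swapping one substituted phenyl for another at this place has so far moved the number by no more than the scatter, so no step beyond the scatter is expected here either, with at most a drift toward the number of compound 2, which also carries a single substituent on the phenyl.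

The expected step in this assay is therefore a 1.4-fold higher number from compound 3 to compound 4 (0.15 log units; within the scatter), within the scatter. Compound 4 is estimated at 11000 nM, with a range from 4500 nM to 28000 nM.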

Compound 4, half-maximal effective concentration: 16000 nM
For compound 4 the middle estimate is 1.5-fold (0.16 log units) below the measured one, within the range that was stated.
By their numbers in this assay, from the lowest: compounds 1, 3, 2 and 4 (each within the scatter of the next, the first and the last beyond it).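

In this assay, among these compounds, 3-(dimethylamino)phenyl in place of 4-chlorophenyl on the oxygen gives the first step at this place that lies beyond the scatter (a 2.1-fold higher number from compound 3 to compound 4 (0.31 log units; beyond the scatter)), though the step is modest and the earlier exchange at this place, a 2.0-fold lower number from compound 2 to compound 3 (0.30 log units; within the scatter), does not reach beyond it. Dimethylamino in place of methoxy on the aromatic carbon leaves the two compounds indistinguishable (a 1.0-fold higher number from compound 2 to compound 4 (0.01 log units; within the scatter)), and 3-(dimethylamino)phenoxy in place of naphthalen-1-yl gives a modest step beyond the scatter (a 2.9-fold higher number from compound 1 to compound 4 (0.46 log units; beyond the scatter)), much like the one already seen with 3-methoxyphenoxy, a 2.8-fold higher number from compound 1 to compound 2 (0.44 log units; beyond the scatter). No measurement offers an explanation for these steps.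

The compounds shown do not separate the identity of the substituent from where it stands on the phenyl: 4-chlorophenyl and 3-(dimethylamino)phenyl differ in both at once. Going by these compounds, how a plain phenyl, or a phenyl carrying a carboxylic acid, on the same oxygen would read in this assay remains open, as does whether any such group would move the number further than the modest steps seen so far.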